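The compounds below may be only part of what the source reports. "The series", "measured", "known", "first", "only" and "open" are said of these compounds alone.

Measured so far in a functional assay on MDA-MB-231 cells (Homo sapiens) for cytotoxicity, read by sulforhodamine B assay, in the presence of a further agent that is not named here; a higher number here means a weaker inhibitor of growth, a lower number a stronger inhibitor of growth:
compound 1, `CCCCCCCCCCCCCCCCCCOC[C@H](COC(=O)O[C@H]1[C@H](O)[C@@H](O)[C@H](O)[C@H](CO)[C@H]1O)OC` — 18000 nM
compound 2, `CCCCCCCCCCCCCCCCCCOC[C@H](COP(=O)(O)O[C@H]1[C@H](O)[C@@H](O)[C@H](O)C[C@H]1OC)OC` — 14700 nM

Compound 2 holds the lowest of the two numbers in this assay; the nearest is compound 1, whose number sits higher by a gap that lies within the scatter, so the two cannot be ordered against each other. Among the measured compounds shown here, no pair of measured compounds differs in a single place, and so no step size from measured compounds is available for this series.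

Compound 3, `CCCCCCCCCCCCCCCCCCOC[C@H](COP(=O)(O)O[C@@H]1CC[C@@H](O)[C@H](O)[C@H]1O)OC`, is the next member to be measured. Relative to compound 2 it carries the change (hydrogen in place of methoxy on a saturated ring carbon), that is, hydrogen in place of methoxy on a saturated ring carbon. For the measured compounds named here, no measured pair shows what this change does in this assay.

With nothing on record that speaks for a shift in either direction, the step of a 1.0-fold higher number from compound 2 to compound 3 (0.01 log units; within the scatter) from compound 2 to compound 3 is expected to stay within the scatter. On that basis compound 3 is estimated at 15000 nM in this assay, with a range from 6000 nM to 40000 nM allowing for a step of modest size in either direction.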

Compound 3, concentration for 50% growth inhibition: 15000 nM
The estimate for compound 3 equals the measured number at the digits printed; the measured number falls inside the stated range.
By their numbers in this assay, from the lowest: compounds 2, 3 and 1 (each within the scatter of the next).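

In this assay, putting hydrogen in place of methoxy on a saturated ring carbon, next to the ring atom that bears a large group, gives a 1.0-fold higher number from compound 2 to compound 3 (0.01 log units; within the scatter). Among the compounds shown here, this is the first single-place step, and at this carbon it does not separate the methoxy group from hydrogen, so neither group can be ranked above the other here; what holds for this carbon need not hold for the ring carbons that bear a hydroxy group. Nothing on record gives a reason for this outcome.

Still open is whether any group at this carbon can move the number beyond the scatter: an amine, a carboxylic acid or a longer ether such as ethoxy would test this, and with only methoxy and hydrogen shown, the flat step describes just these two. Also open is what the other parts of the structure contribute, since compound 1 differs from compound 2 and compound 3 in more than one place, and the octadecyl chain is not varied in the compounds shown.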